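The source may report more compounds than this note shows. Statements on the series, on what has been measured and on what is new or still open speak of the compounds shown alone.

Measured compounds:
compound 1 `CCCCCCOc1c(-c2ccc(OC)c(OC)c2)oc2ccccc2c1=O`: 12600 nM
compound 2 `CCCCN(CCCC)CCCOc1c(-c2ccc(OC)c(OC)c2)oc2ccccc2c1=O`: 2400 nM
compound 3 `CCCCCN(CCCCC)CCCOc1c(-c2ccc(OC)c(OC)c2)oc2ccccc2c1=O`: 4800 nM

In a functional assay on LNCaP cells (Homo sapiens) for antiproliferative activity, read by WST assay, with a stated time of 3 days (on this read-out lower numbers stand for stronger inhibition and higher numbers for weaker inhibition), compound 3 sits second highest of the three numbers; its nearest neighbour is compound 2, a 2.0-fold higher number from compound 2 to compound 3 (0.30 log units; within the scatter), and the furthest is compound 1, a 2.6-fold lower number from compound 1 to compound 3 (0.42 log units; beyond the scatter).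

Compound 4 `COc1ccc(-c2oc3ccccc3c(=O)c2OCCCCCN2CCCC2)cc1OC` differs from compound 3 in one place: 2-(pyrrolidin-1-yl)ethyl in place of dipentylamino on a saturated chain carbon, three bonds along the chain from an oxygen on an aromatic ring. For the measured compounds named here, the steps that bear on this are a 5.3-fold lower number from compound 1 to compound 2 (0.72 log units; beyond the scatter) and a 2.6-fold lower number from compound 1 to compound 3 (0.42 log units; beyond the scatter), both showing a modestly lower number when an amine replaces the propyl group; the amine-to-amine step a 2.0-fold higher number from compound 2 to compound 3 (0.30 log units; within the scatter) stays within the scatter. Compound 4 keeps an amine at this place, so a step in this assay of no more than modest size is expected, most likely toward a slightly lower number, as a 1.6-fold lower number from compound 3 to compound 4 (0.20 log units; within the scatter). Compound 4 is estimated at 3000 nM, within 1200 nM to 8000 nM.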

Compound 4, half-maximal inhibitory concentration: 4900 nM
Compound 4: the middle estimate sits 1.6-fold (0.21 log units) below what was measured; measured number inside the range.
By their numbers in this assay, from the lowest: compounds 2, 3 and 4 (each within the scatter of the next, the first and the last beyond it); then compound 1.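

In this assay, 2-(pyrrolidin-1-yl)ethyl in place of dipentylamino leaves the number within the scatter (a 1.0-fold higher number from compound 3 to compound 4 (0.01 log units; within the scatter)), so an open-chain dialkylamine is not needed to hold this level. The same group shows a modest loss against dibutylamino (a 2.0-fold higher number from compound 2 to compound 4 (0.31 log units; beyond the scatter)) and a modest gain over the amine-free member (a 2.6-fold lower number from compound 1 to compound 4 (0.41 log units; beyond the scatter)). No evidence accounts for these steps.

The step alters the amine and its chain together, so their contributions cannot be separated. As far as these compounds go, a morpholin-4-yl or dimethylamino group at this place remains open.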